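A few compounds are considered here, and "the series" means these few. Any claim that something is new, unique, unknown or untested is made for them only; others in the source may bear on it.

Working notes on the hydrazide series. In a functional assay on OE21 cells (Homo sapiens) for inhibition, read by MTT assay, with a stated time of 72 h (on this read-out higher numbers stand for weaker inhibition and lower numbers for stronger inhibition), compound 1 `O=C(NNC(=O)C1CC1c1ccc(OC(F)(F)F)cc1)c1ccncc1` has "not determined" (no result reported), and compound 3 `CCOc1ccc(C2CC2C(=O)NNc2nncc3ccccc23)cc1` likewise has "not determined" (no result reported). Among the measured compounds shown here, compound 2 `COc1ccc(C2CC2C(=O)NNc2nncc3ccccc23)cc1` is the one member with a number in this assay, giving 48000 nM; it therefore stands alone, with nothing beside it to rank it against. Compound 4 `CC(C)=CCC/C(C)=C/COc1ccc(C2CC2C(=O)NNc2nncc3ccccc23)cc1` is not yet measured. It differs from compound 2 by 2,6-dimethylhepta-1,5-dien-1-yl in place of hydrogen on a saturated chain carbon bound to an oxygen on an aromatic ring. For the measured compounds named here, no step between measured compounds is available for this assay, so any expectation rests on compound 2 alone. From compound 2 at 48000 nM, a step toward stronger inhibition, beyond the scatter, is expected, as a 3.2-fold lower number from compound 2 to compound 4 (0.51 log units; beyond the scatter). Compound 4 is accordingly estimated at 15000 nM, within a range from 4000 nM to 60000 nM.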

Compound 4, half-maximal inhibitory concentration: 9000 nM
Beside the measured number, compound 4's estimate is 1.7-fold (0.22 log units) above it; measured number inside the range.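

In this assay the change on the saturated chain carbon bound to an oxygen on an aromatic ring gives a 5.3-fold lower number from compound 2 to compound 4 (0.73 log units; beyond the scatter) and so shows that this position can carry 3,7-dimethylocta-2,6-dien-1-yl with stronger inhibition than methyl. No data given here bear on why the number falls.

Compounds 1 and 3 carry no number, so steps to them cannot be read. Going by these compounds, it stays open whether the fully saturated 3,7-dimethyloctyl chain, a shorter prenyl chain or a chain ending in an amine would give a comparable step.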